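Working notes before the measurement of compound 3

The compounds below may be only part of what the source reports. "The series", "measured", "known", "first", "only" and "open" are said of these compounds alone.

Measured so far in a functional assay on A498 cells (Homo sapiens) for inhibition, read by sulforhodamine B assay, with a stated time of 48 h, tested at 1 uM; on this read-out higher numbers stand for a weaker effect at the one concentration tested and lower numbers for a stronger effect:
compound 1, `O=C(Nc1cccc(-n2cc(-c3ccncc3)c(-c3cc(O)cc(Cl)c3)n2)c1)Nc1ccc(Cl)c(C(F)(F)F)c1`: 92%
compound 2, `COc1cc(Cl)cc(-c2nn(-c3cccc(NC(=O)Nc4ccc(Cl)c(C(F)(F)F)c4)c3)cc2-c2ccncc2)c1`: 78%

Going by the values given here, compound 2 holds the lowest of the two numbers known in this assay, and the only neighbour is compound 1, which sits higher by the step of a number 14 percentage points lower from compound 1 to compound 2 (beyond the scatter), a change of methyl in place of hydrogen on an oxygen on an aromatic ring.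

Compound 3, `COc1cc(Cl)cc(-c2nn(-c3cccc(NC(=O)c4cccc(C(F)(F)F)c4)c3)cc2-c2ccncc2)c1`, is not yet measured. It differs from compound 2 by 3-(trifluoromethyl)phenyl in place of (4-chloro-3-(trifluoromethyl)phenyl)amino on a carbonyl carbon. Among the compounds with values here, the one measured step, from compound 1 to compound 2, concerns the oxygen on the aromatic ring and leaves the carbonyl end of the molecule untouched, so no measured step bears directly on this change. With nothing in the series to anchor it, the expectation is a step in this assay that is modest at most, most likely upward toward a weaker effect, though a result within the scatter cannot be ruled out.

For compound 3 the estimated value in this assay is 86%, ranging from 62% to 104%. The expected step is therefore a number 8 percentage points higher from compound 2 to compound 3 (within the scatter).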

Compound 3, a percentage reported as activity, at one concentration (the size of the read-out at that concentration, not a potency): 51%
For compound 3 the middle estimate is 35 percentage points above the measured one, outside the stated range (below it).
By their numbers in this assay, from the lowest: compound 3; then compound 2; then compound 1.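

The carbonyl end of the molecule, untouched by the earlier step at the oxygen on the aromatic ring, now proves to be a second place where this assay responds to structure: a number 27 percentage points lower from compound 2 to compound 3 (beyond the scatter). The change at this carbonyl carbon goes in the same direction as a number 14 percentage points lower from compound 1 to compound 2 (beyond the scatter), toward a stronger effect at the one concentration tested, and both steps lie beyond the scatter, though two steps are too few to call this a pattern. The entering 3-(trifluoromethyl)phenyl carries neither the chlorine nor the nitrogen with its hydrogen-bond donor found in the leaving group, and nothing at hand explains why the number falls with this exchange.

The step changes these features together, so the contribution of each remains unresolved; (3-(trifluoromethyl)phenyl)amino and 4-chloro-3-(trifluoromethyl)phenyl on the same carbonyl carbon would separate them. On these data alone, it also remains open whether the gain at the carbonyl end holds when the methoxy group of compound 3 gives way to a hydroxyl group or to an amine.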